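The compounds below may be only part of what the source reports. "The series", "measured", "known", "first", "only" and "open" are said of these compounds alone.

Notes on a three-compound series sharing one core: compound 1 `O=C(CCCCCN(CC(=O)NC1CCCCC1)C(=O)c1ccccc1)NO`, compound 2 `O=C(CCCCCN(CC(=O)NC1CCCCC1)C(=O)c1cccc2ccccc12)NO` and compound 3 `Cc1cc(C)cc(C(=O)N(CCCCCC(=O)NO)CC(=O)NC2CCCCC2)c1`. In a functional assay on CAL-27 cells (Homo sapiens) for cytotoxicity, read by MTT assay, with a stated time of 72 h (on this read-out lower numbers stand for stronger inhibition and higher numbers for weaker inhibition), compound 1 gives 3800 nM, compound 2 gives 2400 nM and compound 3 gives 1130 nM, the lowest of the three numbers. Naphthalen-1-yl in place of phenyl on a carbonyl carbon gives a 1.6-fold lower number from compound 1 to compound 2 (0.20 log units; within the scatter). 3,5-Dimethylphenyl in place of phenyl gives a 3.4-fold lower number from compound 1 to compound 3 (0.53 log units; beyond the scatter), and 3,5-dimethylphenyl in place of naphthalen-1-yl gives a 2.1-fold lower number from compound 2 to compound 3 (0.33 log units; beyond the scatter).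

Compound 4 `Cc1ccc(NC(=O)CN(CCCCCC(=O)NO)C(=O)c2cc(C)cc(C)c2)cc1` keeps the 3,5-dimethylphenyl group of compound 3 and carries 4-methylphenyl in place of cyclohexyl on an amide-type nitrogen. Within the data shown here, none of the measured steps changes the group at this nitrogen, since all three concern the group on the carbonyl carbon. They therefore bear only indirectly, as a guide to step size, and the largest of them is a 3.4-fold lower number from compound 1 to compound 3 (0.53 log units; beyond the scatter). The data give no direction for the new change, so no step beyond the scatter is expected in this assay, and the range is kept wide. The expected step is a 1.1-fold lower number from compound 3 to compound 4 (0.05 log units; within the scatter). For compound 4 the estimated value is 1000 nM, with an expected range of 350 nM to 2900 nM.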

Compound 4, half-maximal inhibitory concentration: 1670 nM
Estimate against measurement, compound 4: 1.7-fold (0.22 log units) below; the range from low to high includes it.
By their numbers in this assay, from the lowest: compounds 3, 4, 2 and 1 (each within the scatter of the next, the first and the last beyond it).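

In this assay, among these compounds, the only measured change at the amide-type nitrogen, 4-methylphenyl in place of cyclohexyl, gives a 1.5-fold higher number from compound 3 to compound 4 (0.17 log units; within the scatter), so with 3,5-dimethylphenyl on the carbonyl carbon, exchanging the non-aromatic ring for the aromatic one produces no step beyond the scatter. The earlier compounds shown here all carry cyclohexyl at this nitrogen and vary only the group on the carbonyl carbon, so they gave no reading of this position; compound 4 provides the first, and it shows that this position accepts a change from a six-membered non-aromatic ring to a methyl-bearing six-membered aromatic ring without a clear shift in this cytotoxicity read-out. No measured property of either group is available to account for this result.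

A single pair cannot show whether the same exchange reads alike with phenyl or naphthalen-1-yl on the carbonyl carbon. Also open, going by these compounds, is how this assay responds to other groups on this nitrogen, such as unsubstituted phenyl, benzyl, 4-fluorophenyl, or a chain ending in an amine or a carboxylic acid.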